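Adding a Third Methoxy Group to Compound 3

This account rests on a few compounds, and the source may have more. Where it says the series, first, only, none or still open, it means among the compounds named here.

Compound 1, `Cc1cc(O)c(C2=NN(c3ccc(S(N)(=O)=O)cc3)C(c3ccccc3O)C2)cc1Cl`, gives 8180 nM in a functional assay on BT-549 cells (Homo sapiens) for antiproliferative activity, with a stated time of 48 h; on this read-out higher numbers stand for weaker inhibition of growth and lower numbers for stronger inhibition of growth.
Compound 2, `Cc1cc(O)c(C2=NN(c3ccc(S(N)(=O)=O)cc3)C(c3ccccc3Cl)C2)cc1Cl`, gives 4740 nM in this assay.
Compound 3, `COc1ccc(C2CC(c3cc(Cl)c(C)cc3O)=NN2c2ccc(S(N)(=O)=O)cc2)cc1OC`, gives 13400 nM in this assay.

Compound 3 stands highest of the three numbers: its distance from compound 1 is a 1.6-fold higher number from compound 1 to compound 3 (0.21 log units; within the scatter), and from compound 2 it is a 2.8-fold higher number from compound 2 to compound 3 (0.45 log units; beyond the scatter). Compound 4, `COc1ccc(C2CC(c3cc(Cl)c(C)cc3O)=NN2c2ccc(S(N)(=O)=O)cc2)c(OC)c1OC`, differs from compound 3 by methoxy in place of hydrogen on an aromatic carbon. Among the measured compounds shown here, no measured step mirrors this change; the two steps that end at compound 3 replace the whole aryl group on the saturated ring carbon rather than add one group to it, and they give only a modest spread. For the measured compounds named here, nothing among the measured compounds therefore points to a step in this assay beyond the scatter, and the same aryl group with one more methoxy is expected to sit close to compound 3, leaning if anything toward a higher number. Compound 4 is thus estimated at 16000 nM, with a range from 6000 nM to 45000 nM. This estimate means a step of a 1.2-fold higher number from compound 3 to compound 4 (0.08 log units; within the scatter) is expected.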

Compound 4, concentration for total growth inhibition: 7010 nM
Estimate against measurement, compound 4: 2.3-fold (0.36 log units) above; low and high end bracket the measured number.
By their numbers in this assay, from the lowest: compounds 2, 4, 1 and 3 (each within the scatter of the next, the first and the last beyond it).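

In this assay, the step from 3,4-dimethoxyphenyl to 2,3,4-trimethoxyphenyl is the first change shown that adds a single group to this aryl ring rather than replacing the whole ring, and methoxy in place of hydrogen on this aromatic carbon, ortho to a large group, stays within the scatter (a 1.9-fold lower number from compound 3 to compound 4 (0.28 log units; within the scatter)). Compound 3 lay beyond the scatter of compound 2 (a 2.8-fold higher number from compound 2 to compound 3 (0.45 log units; beyond the scatter)), but the trimethoxyphenyl group lies within the scatter of both the 2-chlorophenyl group (a 1.5-fold higher number from compound 2 to compound 4 (0.17 log units; within the scatter)) and the 2-hydroxyphenyl group (a 1.2-fold lower number from compound 1 to compound 4 (0.07 log units; within the scatter)), so all three of these aryl groups read alike here. No measurement shown bears on why this added methoxy is tolerated.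

The compounds shown leave open whether a group other than methoxy on this aromatic carbon, such as an amine or a carboxylic acid, would move the number beyond the scatter. They also leave open whether a methoxy on this carbon would read the same without the two neighbouring methoxy groups of compound 4.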